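The compounds below may be only part of what the source reports. "The series", "measured", "known", "first", "only" and "open" are said of these compounds alone.

Measured in a physicochemical assay for solubility, read by spectrophotometry, measured as kinetic solubility, at pH 8, tested at 500 uM; a lower number here means a less soluble compound, a higher number a more soluble compound:
- compound 1 `Cn1ccc2ccc(-c3cc(Nc4ccccc4S(N)(=O)=O)cc4nccnc34)cc21`: 6 ug/mL
- compound 2 `CNC(=O)c1ccncc1Nc1cc(-c2ccc3ccn(C)c3c2)c2nccnc2c1`: 4 ug/mL

In this assay, compound 2 gives 4 ug/mL and compound 1 gives 6 ug/mL, two numbers that lie within the usual scatter of each other, so they cannot be ranked. For the measured compounds named here, the only measured step is a 1.5-fold lower number from compound 1 to compound 2 (0.18 log units; within the scatter). It swaps the group on a nitrogen on an aromatic ring.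

Compound 3 `CN1CCC(NC(=O)c2ccncc2Nc2cc(-c3ccc4ccn(C)c4c3)c3nccnc3c2)CC1=O` differs from compound 2 in one place, with 1-methyl-2-oxopiperidin-4-yl in place of methyl on an amide-type nitrogen. Methylcarbamoyl thus becomes (1-methyl-2-oxopiperidin-4-yl)carbamoyl.

Going by the values given here, no measured pair changes this place, so the step of a 1.5-fold lower number from compound 1 to compound 2 (0.18 log units; within the scatter) is only a loose guide. It shows one exchange of a whole group that left the number within the scatter. With this little evidence, no shift beyond the scatter is expected in this assay, and the data favour no direction. Put as a step, the estimate is a 1.3-fold higher number from compound 2 to compound 3 (0.10 log units; within the scatter). For compound 3 the estimated value is 5 ug/mL, with an expected range of 2 ug/mL to 20 ug/mL.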

Compound 3, solubility: 48 ug/mL
Estimate against measurement, compound 3: 9.6-fold (0.98 log units) below; measured number outside the range, above it.
By their numbers in this assay, from the lowest: compounds 2 and 1 (each within the scatter of the next); then compound 3.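

In this assay, for the compounds shown here, the amide-type nitrogen proves to be a place where the number can move far: 1-methyl-2-oxopiperidin-4-yl in place of methyl gives a 12-fold higher number from compound 2 to compound 3 (1.08 log units; beyond the scatter), whereas the one earlier step, an exchange on a nitrogen on an aromatic ring, stayed within the scatter. The change is a large one in itself, replacing a single carbon with a group of 8 heavy atoms that holds a six-membered non-aromatic ring and adds 1 hydrogen-bond acceptor, while neither group brings a net charge or a hydrogen-bond donor. No measurement here shows which of these features accounts for the step, or how it does so.

A single step also leaves open whether the ring, its carbonyl or its methyl group matters most, and a cyclohexyl group, an unsubstituted piperidin-4-yl ring with its free amine, or a longer chain such as propyl on the same nitrogen would help to separate these parts. Going by these compounds, whether other groups here would give a similar rise remains unknown.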